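Swapping bromo for fluoro on the aryl ester of a chromone

The source may report more compounds than this note shows. Statements on the series, on what has been measured and on what is new or still open speak of the compounds shown alone.

Measured compounds:
Compound 1 `COC(=O)c1c(F)cccc1OC(=O)COc1cc(O)c2c(=O)cc(-c3ccccc3)oc2c1`: 319000 nM
Compound 2 `COC(=O)c1c(Br)cccc1OC(=O)COc1cc(O)c2c(=O)cc(-c3ccccc3)oc2c1`: 388000 nM
Compound 3 `COC(=O)c1cc(Br)ccc1OC(=O)COc1cc(O)c2c(=O)cc(-c3ccccc3)oc2c1`: > 450000 nM

Three compounds sharing a chromone core were tested in an ADME assay on cells (T-cell, Mus musculus, strain BALB/c) for cytotoxicity, read by MTT assay, with a stated time of 48 h; a lower number here means that less compound is tolerated, a higher number that more compound is tolerated. In this assay compound 1 gives 319000 nM, and compound 2 gives 388000 nM. For compound 3 only a limit is known, > 450000 nM, which is the limit of > 450000 nM in this assay, at which 1 of the 3 values shown sits, of this assay. The two numbered values sit within the scatter of each other, so no order between compound 1 and compound 2 can be read from them.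

The change from compound 2 to compound 1 is fluoro in place of bromo on an aromatic carbon, and it made a step of a 1.2-fold lower number from compound 2 to compound 1 (0.09 log units; within the scatter). Compound 4 `COC(=O)c1cc(F)ccc1OC(=O)COc1cc(O)c2c(=O)cc(-c3ccccc3)oc2c1` has not yet been measured; it arises from compound 3 by fluoro in place of bromo on an aromatic carbon. This is the same kind of change, not the same change: in compound 2 the swapped atom sits ortho to a methoxycarbonyl group and meta to a large group, while in compound 3 it sits meta to a methoxycarbonyl group and para to a large group. The two cores themselves differ by a group of 11 heavy atoms (8 carbon, 2 oxygen, 1 bromine; one six-membered aromatic ring of carbon only) in place of a group of 11 heavy atoms (8 carbon, 2 oxygen, 1 bromine; one six-membered aromatic ring of carbon only), on an oxygen next to a carbonyl group, the same atoms joined differently.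

Because the earlier step of a 1.2-fold lower number from compound 2 to compound 1 (0.09 log units; within the scatter) stayed within the scatter, the expected step from compound 3 to compound 4 is also small, a number no higher from compound 3 to compound 4 (the limit leaves the size open). Compound 4 is therefore expected to give about 450000 nM in this assay, with a fair chance that only a limit is reported again.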

Compound 4, half-maximal cytotoxic concentration: 389000 nM
Beside the measured number, compound 4's estimate is 1.2-fold (0.06 log units) above it; measured number inside the range.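

Compound 3 stands at a limit of this assay, not at a number: the limit of > 450000 nM in this assay, at which 1 of the 4 values shown sits.

Fluoro in place of bromo, meta to a methoxycarbonyl group, gives an at least 1.1-fold lower number from compound 3 to compound 4 (0.06 log units; that floor lies within the scatter), and set beside the same swap on the other core, the step looks small both times, though its true size on this core stays unknown: the same change on two cores in this assay, a 1.2-fold lower number (0.09 log units; within the scatter) from compound 2 to compound 1 and an at least 1.1-fold lower number (0.06 log units; that floor lies within the scatter) from compound 3 to compound 4; the limit leaves it open whether they differ

The numbered values also stay close together, with a 1.0-fold higher number from compound 2 to compound 4 (0.00 log units; within the scatter) and a 1.2-fold higher number from compound 1 to compound 4 (0.09 log units; within the scatter). So the swap shows no large effect on either core in this small set, but that does not prove that the two steps are equal, and two pairs of compounds cannot establish a rule for the series.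

The compounds shown leave open whether the same holds when the bromo is replaced by an amine or a trifluoromethyl group, or when a carboxylic acid stands in place of the methoxycarbonyl group. They also leave open whether fluoro in place of bromo would stay this small on a compound with a far lower number in this assay.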